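Removing a Fluorine from an Aryl Amide

This account rests on a few compounds, and the source may have more. Where it says the series, first, only, none or still open, it means among the compounds named here.

Measured so far:
compound 1 `CCC(=O)N1CCc2cc(CNC(=O)c3cccs3)ccc21`: 89%
compound 2 `CC(C)C(=O)N1CCc2cc(CNC(=O)c3ccc(F)cc3)ccc21`: 88%
compound 3 `CCCC(=O)NCc1ccc2c(c1)CCN2C(=O)CC(C)C`: 64%

In an assay on HEK293 cells for inhibition of Indoleamine 2,3-dioxygenase 1 (Homo sapiens), tested at 10 uM (on this read-out lower numbers stand for less inhibition and higher numbers for more inhibition at the one concentration tested (going by the name of the read-out)), compound 1 gives 89% and compound 2 gives 88%. These two numbers lie within the usual scatter of each other. Compound 3 gives 64%, which is clearly lower than compound 2, beyond the scatter. Compound 4 `CC(C)C(=O)N1CCc2cc(CNC(=O)c3ccccc3)ccc21` has not yet been measured. It differs from compound 2 in one place: hydrogen in place of fluoro on an aromatic carbon. For the measured compounds named here, no two measured compounds differ in only one place, so no measured step guides the expectation. Since the fluoro group is a single heavy atom, the expected step in this assay from this change is a number 3 percentage points lower from compound 2 to compound 4 (within the scatter), that is, none beyond the scatter. Compound 4 is therefore estimated at 85%, expected between 70% and 96%.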

Compound 4, a percentage reported as inhibition, at one concentration (the size of the read-out at that concentration, not a potency): 100%
Beside the measured number, compound 4's estimate is 15 percentage points below it; the measured number lies above the stated range.
By their numbers in this assay, from the lowest: compound 3; then compounds 2 and 1 (each within the scatter of the next); then compound 4.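

In this assay the change from 4-fluorophenyl to phenyl gives a number 12 percentage points higher from compound 2 to compound 4 (beyond the scatter), so inhibition at this one concentration does respond to what sits on this aromatic carbon, and the fluoro group is not needed to keep it high. This is the only pair shown that differs in one place, so it is the only direct reading of a single change. Nothing available explains the size or direction of this step.

As far as these compounds go, whether a chloro, methoxy or amine group on the same aromatic carbon would give a similar number remains open. Also open, from the compounds shown here alone, is whether removing the fluoro group would give a similar step with a different acyl group on the shared core.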